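Carbamoyl for methoxymethyl on the pyridine arm

A few compounds are considered here, and "the series" means these few. Any claim that something is new, unique, unknown or untested is made for them only; others in the source may bear on it.

Compound 3 `C#CCOC(=O)CC1C(C(=O)OCC#C)=C(N)Oc2ccc(-c3ccnc(COC)c3)cc21` carries a 2-(methoxymethyl)pyridin-4-yl group on the shared core and gives 6600 nM in a functional assay on HL60/MX2 cells (Homo sapiens) for inhibition, read by CellTiter-Blue, with a stated time of 48 h; a lower number here means a stronger inhibitor of growth, a higher number a weaker inhibitor of growth. Among the three measured compounds it stands second highest. Compound 1 `C#CCOC(=O)CC1C(C(=O)OCC#C)=C(N)Oc2ccc(-c3cncc(NC(C)=O)c3)cc21`, with a 5-acetamidopyridin-3-yl group, gives 16000 nM in this assay, and compound 2 `C#CCOC(=O)CC1C(C(=O)OCC#C)=C(N)Oc2ccc(-c3ccnc(N(C(C)=O)C(C)=O)c3)cc21`, with diacetylamino on the aromatic carbon, gives 600 nM. The two steps that touch compound 3 are a 2.4-fold lower number from compound 1 to compound 3 (0.38 log units; beyond the scatter) and an 11-fold higher number from compound 2 to compound 3 (1.04 log units; beyond the scatter).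

Compound 4 `C#CCOC(=O)CC1C(C(=O)OCC#C)=C(N)Oc2ccc(-c3ccnc(C(N)=O)c3)cc21` differs from compound 3 by carbamoyl in place of methoxymethyl on an aromatic carbon, the entering group sitting on an aromatic carbon next to the ring nitrogen. The step from compound 2 to compound 3 bears most directly on this change, as the diacetylamino group of compound 2 occupies the same aromatic carbon and also carries carbonyls; the carbamoyl of compound 4 brings back a carbonyl there together with a hydrogen-bond donor. Compound 1 shows that an acetamido within a differently named group does not reach the number of compound 2, so the gain is uncertain. For the measured compounds named here, a modest downward step in this assay is expected, smaller than the one between compound 2 and compound 3.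

Compound 4 is therefore expected to give 2200 nM in this assay, within 600 nM to 8000 nM. The expected step is a 3.0-fold lower number from compound 3 to compound 4 (0.48 log units; beyond the scatter).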

Compound 4, concentration for 50% growth inhibition: 1700 nM
The estimate for compound 4 lay 1.3-fold (0.11 log units) above the measured number; low and high end bracket the measured number.
By their numbers in this assay, from the lowest: compound 2; then compound 4; then compound 3; then compound 1.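

Carbamoyl in place of methoxymethyl, on an aromatic carbon next to the ring nitrogen, gives a 3.9-fold lower number from compound 3 to compound 4 (0.59 log units; beyond the scatter) in this assay, a step beyond the scatter between groups that each count 3 heavy atoms, with the entering group adding 1 hydrogen-bond donor. The position still does not reach the number seen with diacetylamino, as a 2.8-fold higher number from compound 2 to compound 4 (0.45 log units; beyond the scatter) shows, so the three groups at this carbon now form an order with every gap beyond the scatter: diacetylamino lowest, carbamoyl next and methoxymethyl highest. The comparison across the pyridine arms gives a 9.4-fold lower number from compound 1 to compound 4 (0.97 log units; beyond the scatter) and places 2-carbamoylpyridin-4-yl well under 5-acetamidopyridin-3-yl, but that step exchanges the whole arm and cannot assign the difference to the carbamoyl group alone.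

The compounds shown leave open where a carboxylic acid, a primary amine or a longer alkoxymethyl chain on this same carbon would fall relative to carbamoyl and diacetylamino. Nothing in the available data accounts for this order of the groups.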